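Trimming a Hydroxymethyl from the Side Chain of Compound 2

This account rests on a few compounds, and the source may have more. Where it says the series, first, only, none or still open, it means among the compounds named here.

Measured so far:
compound 1 `NC(=S)c1c[nH]c2ncnc(N)c12`: 25000 nM
compound 2 `NC(=S)c1cn(COC(CO)CO)c2ncnc(N)c12`: > 100000 nM (a limit of the assay, not a number)

In a functional assay on KB cells (Homo sapiens) for cytotoxicity (a higher number here means a weaker inhibitor, a lower number a stronger inhibitor), compound 1 gives 25000 nM. For compound 2 this assay gives only a limit, > 100000 nM, so compound 2 stands at the limit of > 100000 nM in this assay, at which 1 of the 2 values shown sits. Compound 3 `NC(=S)c1cn(COCCO)c2ncnc(N)c12` differs from compound 2 by hydrogen in place of hydroxymethyl on a saturated chain carbon bound to an oxygen on a saturated carbon and a saturated chain carbon. With only a limit for compound 2, the step is expected to be small, and compound 3 is estimated to reach about 100000 nM, between 30000 nM and 300000 nM.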

Compound 3, half-maximal inhibitory concentration: 115000 nM
For compound 3 the middle estimate is 1.2-fold (0.06 log units) below the measured one; the range from low to high includes it.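

In this assay, (2-hydroxyethoxy)methyl in place of hydrogen on the aromatic nitrogen gives a 4.6-fold higher number from compound 1 to compound 3 (0.66 log units; beyond the scatter) and so a weaker inhibitor. For the compounds shown here, this is the first measured number for a chain at this position, showing that compound 3 keeps a readable effect on the cells. The effect of removing the hydroxymethyl cannot be read, because compound 2 has only a limit of the assay: the limit of > 100000 nM in this assay, at which 1 of the 3 values shown sits.

As far as these compounds go, whether a chain carrying an amine or a carboxylic acid instead would also give a higher number than compound 1 stays open.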